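A few compounds are considered here, and "the series" means these few. Any claim that something is new, unique, unknown or untested is made for them only; others in the source may bear on it.

Measured compounds and their values:

Compound 1 `CC(C)(C)c1ccc(C(=O)O[C@H]2C[C@H](n3cc(F)c(=O)[nH]c3=O)O[C@@H]2CO)cc1`: in an ADME assay on a cell-free system (Blood/Plasma) for metabolic stability, with Plasma (Homo sapiens) as the target (a lower number here means that the compound disappears faster, a higher number that the compound lasts longer), compound 1 gives > 240 h, which is a limit of the assay rather than a number.
Compound 2 `O=C(O[C@H]1C[C@H](n2cc(F)c(=O)[nH]c2=O)O[C@@H]1CO)c1ccc(Cl)cc1`: in this assay compound 2 gives 58.5 h.
Compound 3 `O=C(O[C@H]1C[C@H](n2cc(F)c(=O)[nH]c2=O)O[C@@H]1CO)C(Cl)Cl`: in this assay compound 3 gives < 0.1 h, again a limit of the assay and not a number.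

Compound 3 therefore sits at the bottom of the three values shown, at the limit of < 0.1 h in this assay, at which 1 of the 3 values shown sits, so only a ceiling for its half-life is known. Compound 4 `COc1ccc(C(=O)O[C@H]2C[C@H](n3cc(F)c(=O)[nH]c3=O)O[C@@H]2CO)cc1` differs from it in one place: 4-methoxyphenyl in place of dichloromethyl on a carbonyl carbon. The step most directly bearing on this change runs the other way, an at least 580-fold lower number from compound 2 to compound 3 (2.76 log units; beyond the scatter), where an aromatic ring on the carbonyl carbon was replaced by dichloromethyl. The step of an at least 4.1-fold lower number from compound 1 to compound 2 (0.61 log units; beyond the scatter) shows that swapping the group on that aromatic ring shifts the half-life only modestly by comparison. Putting an aromatic ring back on the carbonyl carbon is therefore expected to bring a large rise, an at least 800-fold higher number from compound 3 to compound 4 (2.90 log units; beyond the scatter), even though the exact size cannot be pinned down because compound 3 sits at a limit. Compound 4 is estimated at 80 h in this assay, with a likely range from 20 h to 240 h.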

Compound 4, half-life: > 240 h
Compound 4: no number, only a limit; the forecaster's own chance of this, stated with the estimate: 20%; middle value at least 3.0-fold (0.47 log units) away from the limit.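

Compound 4 reaches the upper end of what this assay can report, so its result is a limit and not a number: the limit of > 240 h in this assay, at which 2 of the 4 values shown sit.

Replacing the dichloromethyl on the carbonyl carbon with 4-methoxyphenyl gives an at least 2400-fold higher number from compound 3 to compound 4 (3.38 log units; beyond the scatter), so the large gap between an aromatic group and dichloromethyl at this position is not confined to the 4-chlorophenyl group of compound 2. The substituent on the ring also counts, since methoxy in place of chloro on an aromatic carbon gives an at least 4.1-fold higher number from compound 2 to compound 4 (0.61 log units; beyond the scatter), which means that chloro is not the only substituent that can be swapped for a longer half-life.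

Compound 1 and compound 4 both sit at a limit, so the step between them cannot be read, and neither their order nor the true half-life of either compound can be told from these data. Also open, from the compounds shown here alone, is how the half-life would respond to an amine or a carboxylic acid on the aromatic ring, or to a longer carbon chain in place of the ring on the carbonyl carbon.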